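From methoxy to ethynyl in an antiproliferative series

A few compounds are considered here, and "the series" means these few. Any claim that something is new, unique, unknown or untested is made for them only; others in the source may bear on it.

Measured in a functional assay on MDA-MB-231 cells (Homo sapiens) for antiproliferative activity, read by MTT assay, with a stated time of 72 h; on this read-out lower numbers stand for stronger inhibition and higher numbers for weaker inhibition:
Compound 1 `O=C(CCc1cccc2c1B(O)OC2)Nc1ccccc1` gives 230 nM
Compound 2 `O=C(CCc1cccc2c1B(O)OC2)Nc1ccc(Br)cc1` gives 5300 nM
Compound 3 `COc1ccccc1NC(=O)CCc1cccc2c1B(O)OC2` gives 930 nM

Compound 3 stands in the middle of these three values, with compound 1 lower and compound 2 higher, both gaps beyond the scatter. Compound 4 `C#Cc1ccccc1NC(=O)CCc1cccc2c1B(O)OC2` carries ethynyl in place of methoxy on an aromatic carbon, ortho to a large group (ethynyl in place of methoxy on an aromatic carbon). Within the data shown here, no measured step makes this exact exchange. Among the measured compounds shown here, two steps bear on it only indirectly: adding methoxy gave a modest rise (a 4.0-fold higher number from compound 1 to compound 3 (0.61 log units; beyond the scatter)), and adding bromo gave a large one (a 23-fold higher number from compound 1 to compound 2 (1.36 log units; beyond the scatter)). Both substituents raised the number over the hydrogen of compound 1, so ethynyl is expected to leave the value near that of compound 3, with no step beyond the scatter in this assay as the likeliest outcome. The expected step is small (a 1.2-fold lower number from compound 3 to compound 4 (0.07 log units; within the scatter)). The estimate for compound 4 is 800 nM (expected range 200 nM to 3000 nM).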

Compound 4, half-maximal inhibitory concentration: 1300 nM
The estimate for compound 4 lay 1.6-fold (0.21 log units) below the measured number; measured number inside the range.
By their numbers in this assay, from the lowest: compound 1; then compounds 3 and 4 (each within the scatter of the next); then compound 2.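

In this assay, ethynyl in place of methoxy on this aromatic carbon, ortho to a large group, gives a 1.4-fold higher number from compound 3 to compound 4 (0.15 log units; within the scatter), so the assay does not separate these two groups here. Ethynyl carries no hydrogen-bond acceptor where methoxy carries one, yet ethynyl in place of hydrogen still gives a 5.7-fold higher number from compound 1 to compound 4 (0.75 log units; beyond the scatter), a step beyond the scatter and in the same direction as the one seen with methoxy. Nothing measured here accounts for these numbers.

On these data alone, whether an amine or a hydroxyl on this carbon would also give a number higher than that of compound 1 remains open. So does whether ethynyl on another carbon of this ring would behave the same way.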